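Notes on a propylamino step in the acylated series

This account rests on a few compounds, and the source may have more. Where it says the series, first, only, none or still open, it means among the compounds named here.

Three compounds have numbers in a functional assay on PC-3 cells (Homo sapiens) for cytotoxicity, read by MTT assay, with a stated time of 48 h; a higher number here means a weaker inhibitor, a lower number a stronger inhibitor. Compound 1 `CC1=NN(C(=O)c2ccc(C)cc2)C(c2ccccc2O)C1` gives 40600 nM in this assay. Compound 2 `CC(=O)Oc1ccccc1C1CC(C)=NN1C(=O)CCl` gives 3580 nM in this assay. Compound 3 `CCC(=O)N1N=C(c2cc3ccccc3oc2=O)CC1c1ccccc1` gives 4370 nM in this assay. Among these three numbers compound 3 stands second highest; its nearest neighbour is compound 2, whose number lies within the scatter of that of compound 3, so no order between compound 2 and compound 3 can be read from them. Compound 1 lies furthest from compound 3, with a higher number that falls beyond the scatter. No two of these compounds differ in one place only, so no single step between measured compounds is available for guidance.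

Compound 4 `CCCNCC(=O)N1N=C(c2cc3ccccc3oc2=O)CC1c1ccccc1` has not yet been measured in this assay. It differs from compound 3 in one place: propylamino in place of methyl on a saturated chain carbon bound to a carbonyl carbon. Among the compounds with values here, with no measured step of this kind to lean on, the expectation for the step from compound 3 to compound 4 in this assay is a small one, of a size that may not rise beyond the scatter, with a slight lean toward a lower number. The estimate for compound 4 in this assay is 3000 nM, within a range of 1000 nM to 12000 nM. That estimate corresponds to an expected step of a 1.5-fold lower number from compound 3 to compound 4 (0.16 log units; within the scatter).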

Compound 4, half-maximal inhibitory concentration: 7270 nM
Beside the measured number, compound 4's estimate is 2.4-fold (0.38 log units) below it, and the stated range covers the measured number.
By their numbers in this assay, from the lowest: compounds 2, 3 and 4 (each within the scatter of the next, the first and the last beyond it); then compound 1.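

In this assay, within the data shown here, the first single-place step, propylamino in place of methyl on a saturated chain carbon bound to a carbonyl carbon, is a 1.7-fold higher number from compound 3 to compound 4 (0.22 log units; within the scatter) and so gives no order between the two compounds. Among these compounds, this position therefore takes the longer propylamino group, with its added nitrogen, hydrogen-bond donor and hydrogen-bond acceptor, with no change that can be told from the scatter, something the earlier compounds could not show without a step between them. Nothing at hand bears on why this step is so small, and no explanation is offered.

A single step leaves open whether other groups on this chain carbon, such as a dimethylamino group, a carboxylic acid or a longer alkyl chain without nitrogen, would read the same way. Among the compounds shown here, it also leaves open whether this change would behave alike on the core of compound 1 or the core of compound 2, as no single-place step links either of them to compound 3 or compound 4.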